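The compounds below may be only part of what the source reports. "The series", "measured", "known", "first", "only" and "open" are said of these compounds alone.

Measured so far in a functional assay on MCF cells (Homo sapiens) for antiproliferative activity, with a stated time of 72 h; on this read-out lower numbers stand for stronger inhibition and higher numbers for weaker inhibition:
- Compound 1 `OC[C@H]1O[C@@H](n2cnc3c(NCc4ccccc4F)ncnc32)[C@H](O)[C@@H]1O`: > 166000 nM
- Compound 2 `OC[C@H]1O[C@@H](n2cnc3c(NCc4ccc(Br)cc4)ncnc32)[C@H](O)[C@@H]1O`: > 166000 nM
- Compound 3 `Cc1cccc(CNc2ncnc3c2ncn3[C@@H]2O[C@H](CO)[C@@H](O)[C@H]2O)c1`: > 166000 nM

Compound 3 has no true number, because its entry of > 166000 nM is a limit of the assay. The entries for compound 1 and compound 2 are limits too, and all the readings sit at one place: the limit of > 166000 nM in this assay, at which 3 of the 3 values shown sit.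

The unmeasured compound 4 `OC[C@H]1O[C@@H](n2cnc3c(NCc4ccc(Cl)c(Cl)c4)ncnc32)[C@H](O)[C@@H]1O` keeps the core of compound 3 but carries 3,4-dichlorobenzyl in place of 3-methylbenzyl: 3,4-dichlorophenyl in place of 3-methylphenyl on a saturated chain carbon bound to a nitrogen on an aromatic ring.

Three measured swaps at this same place bear on the change: a step that the two limits leave unreadable from compound 1 to compound 3, a step that the two limits leave unreadable from compound 2 to compound 3 and a step that the two limits leave unreadable from compound 1 to compound 2. None of them has a readable size, so they offer no direction. No step beyond the usual scatter is therefore expected in this assay, and another limit is the likeliest report.

The expected change is a step that the limit leaves unreadable from compound 3 to compound 4.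

Compound 4 is estimated at 170000 nM, with an expected range from 70000 nM to 330000 nM.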

Compound 4, half-maximal inhibitory concentration: 88800 nM
For compound 4 the middle estimate is 1.9-fold (0.28 log units) above the measured one; the measured number falls inside the stated range.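

In this assay, for the compounds shown here, compound 4 gives 88800 nM, the first true number in this set rather than a limit, so this position can give a readable result when it carries 3,4-dichlorophenyl. The change gives an at least 1.8-fold lower number from compound 3 to compound 4 (0.27 log units; that floor lies within the scatter), alongside an at least 1.8-fold lower number from compound 2 to compound 4 (0.27 log units; that floor lies within the scatter) and an at least 1.8-fold lower number from compound 1 to compound 4 (0.27 log units; that floor lies within the scatter); each is only a floor, so the real gaps may be larger, but these floors alone do not show a change beyond the usual scatter. The other three compounds stay at one place: the limit of > 166000 nM in this assay, at which 3 of the 4 values shown sit.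

The compounds shown cannot say how much of the change depends on having both chlorines rather than one. From the compounds shown here alone, how a methoxy group or an amine on the phenyl ring, or a longer chain leading to it, would read also remains open.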